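A few compounds are considered here, and "the series" means these few. Any claim that something is new, unique, unknown or untested is made for them only; others in the source may bear on it.

Two compounds have so far been measured in a functional assay for inhibition, tested at 60 ug/mL; a higher number here means a stronger effect of the compound at the concentration tested, a lower number a weaker effect:

Compound 1 `Cc1cc(O)c(C(C)C)cc1-c1cc(-c2cccs2)c(C#N)c(=O)[nH]1` gives 54.3%.
Compound 2 `COc1ccc(-c2cc(-c3cc(C(C)C)c(O)cc3C)[nH]c(=O)c2C#N)cc1OC` gives 52%.

Compound 2 sits with the lower of these two numbers, but the gap to compound 1 is small: the step of a number 2.3 percentage points lower from compound 1 to compound 2 (within the scatter) is within the scatter, so the two compounds cannot be told apart on this measurement. That step was the only one recorded, and it exchanged thiophen-2-yl for 3,4-dimethoxyphenyl on the aromatic carbon opposite the ring nitrogen.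

Compound 3 `Cc1cc(O)c(C(C)C)cc1-c1cc(-c2ccc(N(C)C)cc2)c(C#N)c(=O)[nH]1` has not yet been measured in this assay. It differs from compound 2 as follows: 4-(dimethylamino)phenyl in place of 3,4-dimethoxyphenyl on an aromatic carbon. Among the measured compounds shown here, no measured step places 4-(dimethylamino)phenyl at this position, so the only guide is the single step already seen at the same carbon, which changed nothing beyond the scatter. On that basis compound 3 is expected to give about 52% in this assay, with a plausible range from 35% to 70%. The expected step of no change at the digits printed from compound 2 to compound 3 (within the scatter) is therefore estimated to stay within the scatter, in no clear direction.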

Compound 3, a percentage reported as inhibition, at one concentration (the size of the read-out at that concentration, not a potency): 53%
The estimate for compound 3 lay 1 percentage points below the measured number, within the range that was stated.
By their numbers in this assay, from the lowest: compounds 2, 3 and 1 (each within the scatter of the next).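

Exchanging 3,4-dimethoxyphenyl for 4-(dimethylamino)phenyl on the aromatic carbon opposite the ring nitrogen gives a number 1 percentage points higher from compound 2 to compound 3 (within the scatter) in this assay and putting the same group in place of thiophen-2-yl gives a number 1.3 percentage points lower from compound 1 to compound 3 (within the scatter) on the same read-out. Thiophen-2-yl, 3,4-dimethoxyphenyl and 4-(dimethylamino)phenyl can therefore no longer be told apart at this position, and the comparison now includes an exchange of two methoxy groups for one dimethylamino group on the phenyl ring, which also leaves the read-out within the scatter. No other measurement accompanies these numbers, so the data give no explanation for this similarity.

As far as these compounds go, all three groups at this carbon are aromatic rings, so it remains open whether the read-out would hold with a non-aromatic group there, such as a simple amine, a carboxylic acid or a longer alkyl chain. Every compound also keeps the nitrile and the rest of the shared core unchanged, so the same data say nothing about how a carboxylic acid in place of that nitrile would read.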